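Working notes: from compound 3 to compound 4

This account rests on a few compounds, and the source may have more. Where it says the series, first, only, none or still open, it means among the compounds named here.

Measured so far in a functional assay on HCT-116 cells (Homo sapiens) for inhibition, read by luminescence and resazurin assay, with a stated time of 3 days; on this read-out higher numbers stand for weaker inhibition and lower numbers for stronger inhibition:
compound 1 `CCNc1nc(NCc2ccc(NC(=O)c3ccc(F)cc3)cc2)c2ccccc2n1`: 1400 nM
compound 2 `CCCNc1nc(NCc2ccc(C(=O)NCc3ccc(F)cc3)cc2)c2cc(C)ccc2n1`: 4400 nM
compound 3 `CCCNc1nc(NCc2ccc(C(=O)Nc3ccc(Cl)nc3)cc2)c2cc(C)ccc2n1`: 1500 nM

Compound 3 stands second highest of the three numbers. Its number and that of compound 1 lie within the scatter of each other, so no order between them is claimed; compound 2 is the only one set apart, the step of a 2.9-fold lower number from compound 2 to compound 3 (0.47 log units; beyond the scatter) being beyond the scatter and arising from 6-chloropyridin-3-yl in place of 4-fluorobenzyl on the amide-type nitrogen.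

Compound 4 `Cc1ccc2nc(N(C)C)nc(NCc3ccc(C(=O)Nc4ccc(Cl)nc4)cc3)c2c1` keeps the amide and ring substitution of compound 3 and differs only in the amine on the core: dimethylamino in place of propylamino on an aromatic carbon.

Going by the values given here, no measured step touches this position. Among the compounds with values here, the one step beyond the scatter, from compound 2 to compound 3, sits on the amide side, and compound 1 differs from compound 3 in several places at once, so its number says nothing separable about the amine. With nothing pointing either way, the expectation for compound 4 is a step no larger than the scatter, no change at the digits printed from compound 3 to compound 4 (within the scatter), around the number of compound 3. Compound 4 is therefore estimated at 1500 nM in this assay, with a range from 600 nM to 4000 nM.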

Compound 4, half-maximal inhibitory concentration: 1300 nM
The estimate for compound 4 lay 1.2-fold (0.06 log units) above the measured number, within the range that was stated.
By their numbers in this assay, from the lowest: compounds 4, 1 and 3 (each within the scatter of the next); then compound 2.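

In this assay, the first step read at the amine on the shared core, a 1.2-fold lower number from compound 3 to compound 4 (0.06 log units; within the scatter), gives no change that can be claimed for dimethylamino in place of propylamino on this aromatic carbon. Going by these compounds alone, with the 6-chloropyridin-3-yl amide and the rest of the molecule held fixed, this pair shows that the loss of the hydrogen-bond donor counted on propylamino, together with the shorter count of heavy atoms, comes with no step beyond the scatter, which the earlier compounds could not show because none of their steps isolated this position. No separate measurement bears on this result.

Going by these compounds, the pair spans only two small amines, so it remains open whether an unsubstituted amino group or a longer chain such as hexylamino at this position would give a number beyond the scatter of compound 3. On these data alone, it also remains open whether the same exchange would give a step of similar size on the 4-fluorobenzyl amide of compound 2, since a single pair cannot establish a pattern across the series.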